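A few compounds are considered here, and "the series" means these few. Any claim that something is new, unique, unknown or untested is made for them only; others in the source may bear on it.

Of the compounds shown here, three sharing one core have so far been read in a functional assay on NCI-H460 cells (Homo sapiens) for cytotoxicity, read by MTT assay, with a stated time of 3 days; on this read-out lower numbers stand for stronger inhibition and higher numbers for weaker inhibition. There compound 1 (`N#Cc1c(O)nc(SCc2nc3ccccc3[nH]2)nc1-c1ccccc1`) gives 2.5 nM as its value, compound 2 (`N#Cc1c(Cl)nc(SCc2nc3ccccc3[nH]2)nc1-c1ccccc1`) gives 3.28 nM as its value and compound 3 (`CNc1nc(SCc2nc3ccccc3[nH]2)nc(-c2ccccc2)c1C#N`) gives 3.2 nM as its value, which places compound 3 within the scatter of both others. Compound 4 (`N#Cc1c(Nc2ccccn2)nc(SCc2nc3ccccc3[nH]2)nc1-c1ccccc1`) differs from compound 3 by having pyridin-2-yl in place of methyl on a nitrogen on an aromatic ring. The measured steps that bear on this all exchange a group on an aromatic carbon: there is a 1.3-fold higher number from compound 1 to compound 2 (0.12 log units; within the scatter) and a 1.3-fold higher number from compound 1 to compound 3 (0.11 log units; within the scatter) and a 1.0-fold lower number from compound 2 to compound 3 (0.01 log units; within the scatter) and none of them leaves the scatter. Going by the values given here, no measured compound carries a ring on that nitrogen, so the data offer no direct test and the range stays wide. In this assay no step beyond the scatter is expected, and no direction is favoured. The expected step is a 1.1-fold higher number from compound 3 to compound 4 (0.04 log units; within the scatter) on this estimate. For compound 4 the estimated value is 3.5 nM with an expected range from 1.2 nM to 12 nM as its span.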

Compound 4, half-maximal inhibitory concentration: 2.8 nM
The estimate for compound 4 lay 1.3-fold (0.10 log units) above the measured number; the range from low to high includes it.
By their numbers in this assay, from the lowest: compounds 1, 4, 3 and 2 (each within the scatter of the next).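

In this assay, going by these compounds alone, the nitrogen on an aromatic ring now carries a ring for the first time, and pyridin-2-yl in place of methyl gives a 1.1-fold lower number from compound 3 to compound 4 (0.06 log units; within the scatter). The comparisons with the other two groups on that aromatic carbon read the same way, with a 1.2-fold lower number from compound 2 to compound 4 (0.07 log units; within the scatter) and a 1.1-fold higher number from compound 1 to compound 4 (0.05 log units; within the scatter), so hydroxy, chloro, methylamino and (pyridin-2-yl)amino all stand within the scatter of one another at this place. Nothing on hand offers an explanation for this flat read-out.

The compounds shown leave open whether phenyl, which lacks the ring nitrogen of pyridin-2-yl, would read the same on that nitrogen. They also leave open whether a longer chain or a carboxylic acid there would stay within the scatter.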